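Pyridin-2-yl to 4-nitrophenyl: a step still unmeasured

This account rests on a few compounds, and the source may have more. Where it says the series, first, only, none or still open, it means among the compounds named here.

In a toxicity assay on cells (Macrophage, Mus musculus, strain BALB/c) for cytotoxicity, read by MTT assay (a lower number here means a stronger inhibitor, a higher number a weaker inhibitor), three compounds sharing one core have numbers: compound 1 `C=CCOc1cc(OC)c(C(=O)/C=C/c2ccc(F)cc2)c(OCC=C)c1` reads 13800 nM and compound 2 `C=CCOc1cc(OC)c(C(=O)/C=C/c2ccccc2Br)c(OCC=C)c1` reads 5400 nM while compound 3 `C=CCOc1cc(OC)c(C(=O)/C=C/c2ccccn2)c(OCC=C)c1` reads 12500 nM in the same series. Compound 3 sits level with compound 1, and both stand above compound 2.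

Compound 4 `C=CCOc1cc(OC)c(C(=O)/C=C/c2ccc([N+](=O)[O-])cc2)c(OCC=C)c1` changes compound 3 at one place, on a double-bonded chain carbon bound to a double-bonded chain carbon: 4-nitrophenyl in place of pyridin-2-yl (4-nitrophenyl in place of pyridin-2-yl on a double-bonded chain carbon bound to a double-bonded chain carbon).

Three measured swaps at that same place bear on this. Pyridin-2-yl in place of 4-fluorophenyl stayed within the scatter (a 1.1-fold lower number from compound 1 to compound 3 (0.04 log units; within the scatter)). The only modest moves involve 2-bromophenyl (a 2.6-fold lower number from compound 1 to compound 2 (0.41 log units; beyond the scatter)) and (a 2.3-fold higher number from compound 2 to compound 3 (0.36 log units; beyond the scatter)), and that group is not part of the new change. With just three compounds, this is thin support.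

No step beyond the scatter is expected in this assay, and the estimated step is a slight one toward a lower number (a 1.1-fold lower number from compound 3 to compound 4 (0.06 log units; within the scatter)). For compound 4 the expected value is 11000 nM (estimated range 5000 nM to 22000 nM).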

Compound 4, half-maximal inhibitory concentration: 13200 nM
Beside the measured number, compound 4's estimate is 1.2-fold (0.08 log units) below it; low and high end bracket the measured number.
By their numbers in this assay, from the lowest: compound 2; then compounds 3, 4 and 1 (each within the scatter of the next).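

At this place, on a double-bonded chain carbon bound to a double-bonded chain carbon, 4-nitrophenyl reads level with pyridin-2-yl (a 1.1-fold higher number from compound 3 to compound 4 (0.02 log units; within the scatter)) in this assay, and nitro in place of fluoro on an aromatic carbon also stays level (a 1.0-fold lower number from compound 1 to compound 4 (0.02 log units; within the scatter)). The entering group holds 9 heavy atoms against 6 in the one leaving, and it has 2 hydrogen-bond acceptors against 1, yet neither difference comes with a step beyond the scatter. Within the data shown here, compound 2 now stands apart from three level compounds rather than two (a 2.4-fold higher number from compound 2 to compound 4 (0.39 log units; beyond the scatter)), so 2-bromophenyl is the only group here that goes against an otherwise flat reading.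

Still open, on these data alone, is whether an amine or a carboxylic acid on that aromatic ring would move the number, and whether bromo gives the lower number of compound 2 at any other ring position. No measurement at hand accounts for the flat reading or for the exception.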